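This account rests on a few compounds, and the source may have more. Where it says the series, first, only, none or still open, it means among the compounds named here.

Compound 1 `Cc1ncc(CN2CCC3(CCCN(Cc4ccc(C(C)C)cc4)C3=O)C2)cn1` gives 62700 nM in an ADME assay on HepG2 cells (Homo sapiens) for cytotoxicity, read by luminescence and CellTiter-Glo, with a stated time of 24 h; a higher number here means that more compound is tolerated, a lower number that less compound is tolerated. Compound 2 `CC(C)c1ccc(CN2CCCC3(CCN(CC4CCSCC4)C3)C2=O)cc1` gives 62700 nM in this assay. Compound 3 `CC(C)c1ccc(CN2CCCC3(CCN(Cc4cccnc4)C3)C2=O)cc1` gives 62700 nM in this assay.

Compound 3 thus stands level with compounds 1 and 2; the steps of no change at the digits printed from compound 1 to compound 2 (within the scatter), no change at the digits printed from compound 1 to compound 3 (within the scatter) and no change at the digits printed from compound 2 to compound 3 (within the scatter) all stay within the scatter. Compound 4 `Cc1c(CN2CCC3(CCCN(Cc4ccc(C(C)C)cc4)C3=O)C2)cnn1C` has not yet been measured in this assay. It differs from compound 3 by 1,5-dimethyl-1H-pyrazol-4-yl in place of pyridin-3-yl on a saturated chain carbon bound to an amine nitrogen in a ring. Every measured step exchanged the group on the same saturated chain carbon bound to an amine nitrogen in a ring, and none moved the reading beyond the scatter, so for compound 4 no step beyond the scatter is expected, no change at the digits printed from compound 3 to compound 4 (within the scatter). Compound 4 is therefore estimated at 62700 nM, between 31000 nM and 63000 nM.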

Compound 4, half-maximal cytotoxic concentration: 62700 nM
Compound 4: middle estimate and measured number agree at the digits printed; low and high end bracket the measured number.
By their numbers in this assay, from the lowest: compounds 1, 2, 3 and 4 (each within the scatter of the next).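

In this assay, the saturated chain carbon bound to an amine nitrogen in a ring now also carries a five-membered aromatic ring with 2 hetero atoms, whereas the earlier groups all held six-membered rings, and the reading shows no change at the digits printed from compound 3 to compound 4 (within the scatter). The comparisons with the other two groups agree, with no change at the digits printed from compound 2 to compound 4 (within the scatter) and no change at the digits printed from compound 1 to compound 4 (within the scatter). No evidence on the cause of this is at hand.

On these data alone, whether an amine or a carboxylic acid on this carbon would move the reading stays open. So does the effect of any exchange elsewhere on the shared core.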